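This account rests on a few compounds, and the source may have more. Where it says the series, first, only, none or still open, it means among the compounds named here.

For the measured compounds named here, in a toxicity assay on cells (Macrophage, Mus musculus, strain BALB/c) for cytotoxicity, read by MTT assay (a higher number here means a weaker inhibitor, a lower number a stronger inhibitor), compound 2 `COc1ccc(/C=C/C(=O)c2c(O)cc(O)cc2OC)cc1` gives 166000 nM, the higher of the two numbers so far, while compound 1 `COc1cc(O)cc(O)c1C(=O)/C=C/c1ccc(C)cc1` gives 16500 nM. Compound 3 `COc1cc(O)cc(O)c1C(=O)/C=C/c1ccc(C(F)(F)F)cc1` differs from compound 2 by trifluoromethyl in place of methoxy on an aromatic carbon. Going by the values given here, only one measured step bears on this change: a 10-fold higher number from compound 1 to compound 2 (1.00 log units; beyond the scatter), a modest step that brought methoxy in place of methyl. As far as these compounds go, removing methoxy may reverse that step, although trifluoromethyl itself is untested. The expected change is a 6.6-fold lower number from compound 2 to compound 3 (0.82 log units; beyond the scatter), toward a lower number and of similar size. For compound 3 the estimate is 25000 nM, with an expected range of 7000 nM to 80000 nM.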

Compound 3, half-maximal inhibitory concentration: 17100 nM
Compound 3: the middle estimate sits 1.5-fold (0.16 log units) above what was measured; measured number inside the range.
By their numbers in this assay, from the lowest: compounds 1 and 3 (each within the scatter of the next); then compound 2.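

In this assay, trifluoromethyl in place of methoxy gives a 9.7-fold lower number from compound 2 to compound 3 (0.99 log units; beyond the scatter) and so shows that the earlier step at this position can be undone by a group other than methyl. Trifluoromethyl and methyl cannot be told apart here, with a 1.0-fold higher number from compound 1 to compound 3 (0.02 log units; within the scatter) between them. Of the three groups at this position, methoxy alone stands apart from the other two.

As far as these compounds go, whether an amine or a carboxylic acid at this position would group with methoxy or with the other two remains open. Nothing available explains why methoxy stands apart.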